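The source may report more compounds than this note shows. Statements on the series, on what has been measured and on what is new or still open speak of the compounds shown alone.

Measured compounds:
- compound 1, `COC(=O)c1sc2cc(-c3ccsc3)cnc2c1N`: 12700 nM
- compound 2, `COC(=O)c1sc2cc(-c3cnn(C)c3)cnc2c1N`: > 150000 nM

Compound 1 is the only compound among these two with a number in a functional assay on MCF7 cells (Homo sapiens) for inhibition, read by sulforhodamine B assay, with a stated time of 48 h (a lower number here means a stronger inhibitor of growth, a higher number a weaker inhibitor of growth), where compound 1 gives 12700 nM. For compound 2 this assay reports only a limit, > 150000 nM, and the step of an at least 11-fold higher number from compound 1 to compound 2 (1.07 log units; beyond the scatter) therefore tells just how far the weakening at least reaches. Within the data shown here, the one further point of evidence is the limit of > 150000 nM in this assay, at which 1 of the 2 values shown sits.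

Compound 3, `COC(=O)c1sc2cc(-c3cccnc3)cnc2c1N`, has not yet been measured. It differs from compound 1 in a single change, (pyridin-3-yl in place of thiophen-3-yl on an aromatic carbon). Among the measured compounds shown here, the only measured step at this same place is the one from compound 1 to compound 2, which was large and pointed toward weaker inhibition. The change to pyridin-3-yl is smaller than that change, so a weakening beyond the scatter is expected, but a less severe one.

For compound 3 in this assay a value of about 32000 nM is estimated, within a range from 8000 nM to 150000 nM, which would mean an expected step of a 2.5-fold higher number from compound 1 to compound 3 (0.40 log units; beyond the scatter).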

Compound 3, concentration for 50% growth inhibition: > 112000 nM
Compound 3 was reported as a limit; the forecaster's own chance of this, stated with the estimate: 30%; middle value at least 3.5-fold (0.54 log units) away from the limit.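

In this assay compound 3 also gives only a limit, > 112000 nM. Among these compounds, with an at least 8.8-fold higher number from compound 1 to compound 3 (0.94 log units; beyond the scatter), the loss at this position is no longer confined to the 1-methyl-1H-pyrazol-4-yl group: pyridin-3-yl, a six-membered aromatic ring, also weakens growth inhibition beyond the scatter, leaving thiophen-3-yl as the only group here with a number rather than a limit. Compound 2 and compound 3 both carry limits, and the step from compound 2 to compound 3 cannot be read.

On these data alone, how much weaker either compound truly is remains open, and so does their order. Also open, as far as these compounds go, is whether a phenyl ring or a thiophen-2-yl group at this place would keep the inhibition of compound 1 or improve on it.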